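Aryl group change from compound 3 to compound 4

The source may hold more compounds than are shown below. What is called first, only, known or untested is meant among the compounds shown, and "the series" means these compounds.

In a functional assay on SGC-7901 cells (Homo sapiens) for inhibition, read by MTT assay, with a stated time of 24 h (a lower number here means a stronger inhibitor, a higher number a weaker inhibitor), compound 1 `CC1(C)[C@H]2CC[C@]1(C)N(Cc1cn(-c3ccccc3F)nn1)C(=O)C2` gives 300 nM and compound 2 `CC1(C)[C@H]2CC[C@]1(C)N(Cc1cn(-c3ccccc3)nn1)C(=O)C2` gives 240 nM while compound 3 `Cc1ccc(-n2cc(CN3C(=O)C[C@@H]4CC[C@@]3(C)C4(C)C)nn2)cc1` gives 390 nM so compound 3 stands within the scatter of both others. Compound 4 `CC1(C)[C@H]2CC[C@]1(C)N(Cc1cn(-c3cccc(O)c3)nn1)C(=O)C2` carries 3-hydroxyphenyl in place of 4-methylphenyl on an aromatic nitrogen at the same aryl position. Within the data shown here, three measured steps bear on this change: a 1.3-fold lower number from compound 1 to compound 2 (0.10 log units; within the scatter) and then a 1.3-fold higher number from compound 1 to compound 3 (0.11 log units; within the scatter) and also a 1.6-fold higher number from compound 2 to compound 3 (0.21 log units; within the scatter) as the only guides. Among the measured compounds shown here, no measured compound carries a hydroxy group, so this support is indirect. The expected change is a 1.3-fold lower number from compound 3 to compound 4 (0.11 log units; within the scatter) in this assay and so no step beyond the scatter is expected. Compound 4 is estimated at 300 nM with an expected range from 120 nM to 750 nM in this series.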

Compound 4, half-maximal inhibitory concentration: 270 nM
Beside the measured number, compound 4's estimate is 1.1-fold (0.05 log units) above it, within the range that was stated.
By their numbers in this assay, from the lowest: compounds 2, 4, 1 and 3 (each within the scatter of the next).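

In this assay, 3-hydroxyphenyl on the aromatic nitrogen brings a hydrogen-bond donor and acceptor into the aryl group, yet the steps remain small: a 1.4-fold lower number from compound 3 to compound 4 (0.16 log units; within the scatter), a 1.1-fold higher number from compound 2 to compound 4 (0.05 log units; within the scatter) and a 1.1-fold lower number from compound 1 to compound 4 (0.05 log units; within the scatter). All four aryl groups shown at this position thus lie within the scatter of one another, so this position shows no measurable preference among them. Nothing available explains this flat result. As far as these compounds go, whether an amine, a carboxylic acid or a longer chain on the phenyl ring would give a step beyond the scatter remains open.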